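Notes on the 4-methylphenyl to 3,4-dimethylphenyl step

This account rests on a few compounds, and the source may have more. Where it says the series, first, only, none or still open, it means among the compounds named here.

Measured so far:
compound 1 `CCCc1nc(-c2ccccc2)c(CNCCCN2CCN(c3cccc(F)c3)CC2)o1`: 68.9%
compound 2 `CCCc1nc(-c2ccccc2)c(CNCCCN2CCN(c3ccc(C)cc3)CC2)o1`: 53.9%

In an assay on HEK293 cells for inhibition of Voltage-dependent T-type calcium channel subunit alpha-1G (Homo sapiens), read by fluorescence, tested at 10 uM (on this read-out lower numbers stand for less inhibition and higher numbers for more inhibition at the one concentration tested (going by the name of the read-out)), compound 2 stands lowest of the two numbers, the nearest being compound 1, which sits higher by the step of a number 15 percentage points lower from compound 1 to compound 2 (beyond the scatter). Within the data shown here, that step, 4-methylphenyl in place of 3-fluorophenyl on an amine nitrogen in a ring, is the only measured step and it does not involve a hydrogen-to-methyl exchange.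

Compound 3 `CCCc1nc(-c2ccccc2)c(CNCCCN2CCN(c3ccc(C)c(C)c3)CC2)o1` differs from compound 2 by methyl in place of hydrogen on an aromatic carbon. Among the measured compounds shown here, no measured step bears directly on this difference, so the expectation rests on compound 2 alone, with a wide range. The change from compound 2 to compound 3 is expected to be a number 0.9 percentage points lower from compound 2 to compound 3 (within the scatter), i.e. nothing beyond the scatter. Compound 3 is therefore estimated at 53%, between 32% and 74%.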

Compound 3, a percentage reported as inhibition, at one concentration (the size of the read-out at that concentration, not a potency): 54.6%
Estimate against measurement, compound 3: 1.6 percentage points below; low and high end bracket the measured number.
By their numbers in this assay, from the lowest: compounds 2 and 3 (each within the scatter of the next); then compound 1.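

In this assay, a methyl in place of hydrogen on an aromatic carbon, ortho to a methyl group, gives a number 0.7 percentage points higher from compound 2 to compound 3 (within the scatter), so at this position the second methyl on the ring leaves compound 2 and compound 3 within the scatter of each other. The 3,4-dimethylphenyl group also stays short of the 3-fluorophenyl group, with a number 14.3 percentage points lower from compound 1 to compound 3 (beyond the scatter), and this matches the size of a number 15 percentage points lower from compound 1 to compound 2 (beyond the scatter). Nothing available here accounts for either the flat methyl step or the gap to compound 1.

The compounds shown leave open whether a chlorine, a methoxy group or an amine in place of this methyl would also stay within the scatter of compound 2. They also leave open whether a fluorine at this same position would bring the number closer to that of compound 1.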